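Swapping fluoro for chloro on the benzyl ether

A few compounds are considered here, and "the series" means these few. Any claim that something is new, unique, unknown or untested is made for them only; others in the source may bear on it.

Compound 1 `COc1cc(OC)c(-c2coc3cc(OCc4ccccc4C)ccc3c2=O)cc1OC`: 2000 nM
Compound 2 `COc1cc(OC)c(-c2coc3cc(OCc4cccc(F)c4)ccc3c2=O)cc1OC`: 3510 nM

In a functional assay on U-251 cells (Homo sapiens) for antiproliferative activity, read by MTT assay, with a stated time of 24 h (on this read-out lower numbers stand for stronger inhibition and higher numbers for weaker inhibition), compound 2 gives 3510 nM. Going by the values given here, the only other measured compound, compound 1, gives 2000 nM, and the two values lie within the scatter of each other, so neither can be ranked above the other.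

The next compound is compound 3 `COc1cc(OC)c(-c2coc3cc(OCc4cccc(Cl)c4)ccc3c2=O)cc1OC`. It keeps the shared core and differs from compound 2 by chloro in place of fluoro on an aromatic carbon. In words, this is chloro in place of fluoro on an aromatic carbon, so that 3-fluorobenzyl becomes 3-chlorobenzyl.

Among the compounds with values here, no measured step compares these two groups directly. Within the data shown here, the one step that touches this part of the structure replaces 2-methylphenyl with 3-fluorophenyl, and it amounts to a 1.8-fold higher number from compound 1 to compound 2 (0.24 log units; within the scatter). That is a larger exchange than the one at hand, and it did not leave the scatter, so nothing points to a real shift in this assay. The expected change is a 1.2-fold lower number from compound 2 to compound 3 (0.07 log units; within the scatter), which means no step beyond the scatter is anticipated. For compound 3 the estimated value is 3000 nM, with an expected range from 1400 nM to 6000 nM.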

Compound 3, half-maximal inhibitory concentration: > 10000 nM
Compound 3: no number, only a limit (the forecaster's own chance of this, stated with the estimate: 5%); at least 3.3-fold (0.52 log units) between middle value and limit.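

In this assay compound 3 gives > 10000 nM, which is a limit of the assay and not a number. Going by these compounds alone, the only earlier step at this benzyl ether stayed within the scatter, even though it exchanged one whole aryl group for another, whereas replacing a single fluoro with chloro on the same aromatic carbon gives an at least 2.8-fold higher number from compound 2 to compound 3 (0.45 log units; beyond the scatter), so this position responds to a change of one atom and the response runs towards weaker inhibition. Measured against the 2-methylphenyl group, the 3-chlorophenyl group gives an at least 5.0-fold higher number from compound 1 to compound 3 (0.69 log units; beyond the scatter), and both new steps are minimum sizes whose true extent stays unknown, since the reading stops at the top of the range: the limit of > 10000 nM in this assay, at which 1 of the 3 values shown sits.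

The compounds shown do not tell whether this weakening is specific to chloro, since a bromo, methyl or methoxy group on the same aromatic carbon, or a plain unsubstituted benzyl ether, could place the result in a wider series. They also leave open whether chloro would have the same effect on another carbon of this ring, as in 2-chlorobenzyl or 4-chlorobenzyl.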